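Compound 3 to compound 4: 4-nitrophenyl for 2-fluorophenyl

The source may hold more compounds than are shown below. What is called first, only, known or untested is meant among the compounds shown, and "the series" means these compounds.

In an ADME assay on MT4 cells (Homo sapiens) for cytotoxicity, read by MTT assay, with a stated time of 5 days (a higher number here means that more compound is tolerated, a lower number that less compound is tolerated), compound 3 (`Cc1cnc(Nc2ccc(C#N)cc2)nc1OCC(=O)Nc1ccccc1F`) gives > 331000 nM, which is a limit of the assay and not a number. Compound 1 (`N#Cc1ccc(NC(=O)COc2ccnc(Nc3ccc(C#N)cc3)n2)cc1`) gives > 337000 nM, also a limit. All three measured compounds therefore stand at limits, and no order among them can be read.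

Compound 4 (`Cc1cnc(Nc2ccc(C#N)cc2)nc1OCC(=O)Nc1ccc([N+](=O)[O-])cc1`) has 4-nitrophenyl in place of 2-fluorophenyl on an amide-type nitrogen.

Compound 2 (`Cc1cc(OCC(=O)Nc2ccc([N+](=O)[O-])cc2)nc(Nc2ccc(C#N)cc2)n1`) carries the same 4-nitrophenyl and gives > 309000 nM, again a limit, and the expectation rests on that reading. No step beyond the scatter is expected in this assay. The estimated change is an at least 1.1-fold lower number from compound 3 to compound 4 (0.07 log units; that floor lies within the scatter). Compound 4 is expected at 280000 nM, with an estimated range of 80000 nM to 340000 nM.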

Compound 4, half-maximal cytotoxic concentration: 66300 nM
Beside the measured number, compound 4's estimate is 4.2-fold (0.63 log units) above it; measured number outside the range, below it.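

In this assay, the amide-type nitrogen proves to be a place where a change can be read: 4-nitrophenyl in place of 2-fluorophenyl gives an at least 4.9-fold lower number from compound 3 to compound 4 (0.69 log units; beyond the scatter). Among these compounds, this position therefore does not accept every aryl group without a measurable drop, something the earlier compounds, all at limits, could not show. The step is only a floor because compound 3 stands at a limit: the limit of > 331000 nM in this assay, at which 1 of the 4 values shown sits.

Which part of 4-nitrophenyl carries the drop stays open. A 4-aminophenyl or an unsubstituted phenyl on the same nitrogen would separate the nitro group from the ring.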